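Urea series: tert-butyl in place of phenoxy

The source may hold more compounds than are shown below. What is called first, only, known or untested is meant among the compounds shown, and "the series" means these compounds.

Measured so far:
compound 1, `CN(C)CCC(NC(=O)Nc1ccc(-c2ccccc2)cc1)c1ccc(Cl)cc1`, 145 nM in an assay on NIH3T3 cells with Urotensin-2 receptor (Homo sapiens) as the target; on this read-out higher numbers stand for an effect only at larger amounts of compound and lower numbers for an effect already at smaller amounts
compound 2, `CN(C)CCC(NC(=O)Nc1ccc(Oc2ccccc2)cc1)c1ccc(Cl)cc1`, 110 nM in this assay

Going by the values given here, compound 2 gives the lowest of the two numbers; compound 1 sits nearest, and the only step between them, a 1.3-fold lower number from compound 1 to compound 2 (0.12 log units; within the scatter), stays within the scatter. Compound 3, `CN(C)CCC(NC(=O)Nc1ccc(C(C)(C)C)cc1)c1ccc(Cl)cc1`, is not yet measured. Its change from compound 2 is tert-butyl in place of phenoxy on an aromatic carbon, at the same position as the earlier exchange. Among the compounds with values here, only that one step bears on it, and it was small, so no step beyond the scatter is expected in this assay. For compound 3 the expected value is 150 nM, range 50 nM to 500 nM, meaning a step of a 1.4-fold higher number from compound 2 to compound 3 (0.13 log units; within the scatter).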

Compound 3, half-maximal effective concentration: 275 nM
For compound 3 the middle estimate is 1.8-fold (0.26 log units) below the measured one; low and high end bracket the measured number.
By their numbers in this assay, from the lowest: compounds 2, 1 and 3 (each within the scatter of the next, the first and the last beyond it).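

In this assay, going by these compounds alone, this position proves not to be indifferent to the group it carries: tert-butyl, which has no ring, gives the first step here beyond the scatter, though a modest one (a 2.5-fold higher number from compound 2 to compound 3 (0.40 log units; beyond the scatter)). Against phenyl, the same group stays within the scatter (a 1.9-fold higher number from compound 1 to compound 3 (0.28 log units; within the scatter)), so the exchange separates tert-butyl only from phenoxy. No data at hand account for this step.

On these data alone, whether a methyl group, an amine or a carboxylic acid on this aromatic carbon would fall within this range remains open. Also open is whether the oxygen of phenoxy contributes to the step, since no listed compound changes it alone.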